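The source may hold more compounds than are shown below. What is called first, only, known or untested is meant among the compounds shown, and "the series" means these compounds.

Measured compounds:
- Compound 1 `O=c1[nH]cc(S(=O)(=O)Nc2cccc(-c3cn(-c4ccccc4)nn3)c2)c(=O)[nH]1`: 11200 nM
- Compound 2 `O=c1[nH]cc(S(=O)(=O)Nc2ccc(-c3cn(-c4ccccc4)nn3)cc2)c(=O)[nH]1`: 18000 nM

In a functional assay on HepG2 cells (Homo sapiens) for antiproliferative activity, read by MTT assay, with a stated time of 24 h (on this read-out higher numbers stand for weaker inhibition and lower numbers for stronger inhibition), compound 2 gives 18000 nM, the higher of the two numbers, while compound 1 gives 11200 nM; the two lie within the scatter of each other, so no order between them can be read from this assay. Compound 3 `Cc1cccc(-n2cc(-c3ccc(NS(=O)(=O)c4c[nH]c(=O)[nH]c4=O)cc3)nn2)c1` differs from compound 2 by one small change: methyl in place of hydrogen on an aromatic carbon, a methyl in place of hydrogen on an aromatic carbon. Among the measured compounds shown here, no pair of measured compounds shows what such a change does here, so no direction can be inferred from the data. A single added carbon of this kind is usually a small step, and with nothing to point either way the estimate for compound 3 stays close to compound 2, a step of a 1.1-fold lower number from compound 2 to compound 3 (0.02 log units; within the scatter). In this assay compound 3 is therefore expected at about 17000 nM, with a range from 7000 nM to 40000 nM.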

Compound 3, half-maximal inhibitory concentration: > 20000 nM
Compound 3: a limit, no number; the forecaster's own chance of this, stated with the estimate: 5%; at least 1.1-fold (0.07 log units) between middle value and limit.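

In this assay compound 3 gives > 20000 nM, which is a limit of the assay and not a number. Among the compounds shown here, this is the first reading for a methyl on this outer ring, the change from phenyl to 3-methylphenyl, and it gives only a floor: an at least 1.1-fold higher number from compound 2 to compound 3 (0.04 log units; that floor lies within the scatter). The added methyl brings no sign of stronger inhibition, but the size of its effect cannot be read, and the reading for compound 3 is the only one of its kind here: the limit of > 20000 nM in this assay, at which 1 of the 3 values shown sits.

Going by these compounds, how far the true value of compound 3 lies past that limit remains open, and so does whether the methyl changes inhibition at all. Also open, on these data alone, is what other groups at this place would do, such as an ethyl chain, a methoxy group, an amine or a carboxylic acid.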